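Swapping the carbamoyl for hydroxymethyl on a biphenyl antagonist

The compounds below may be only part of what the source reports. "The series", "measured", "known", "first", "only" and "open" are said of these compounds alone.

Compound 1, `NC(=O)Cc1ccccc1-c1ccc(COC2CC[C@H](N3CCCCCC3)[C@H]2OC/C=C\CCC(=O)O)cc1`: 158 nM
Compound 2, `O=C(O)CC/C=C\CO[C@H]1[C@@H](OCc2ccc(-c3ccccc3CO)cc2)CC[C@@H]1N1CCCCCC1`: 12.6 nM
Compound 3, `NC(=O)c1ccccc1-c1ccc(COC2CC[C@H](N3CCCCCC3)[C@H]2OC/C=C\CCC(=O)O)cc1`: 15.9 nM

Within the data shown here, in a functional assay for antagonist activity at thromboxane A2 receptor (Rattus norvegicus) (on this read-out lower numbers stand for tighter binding and higher numbers for weaker binding), compound 3 stands second of the three, close to compound 2 and far from compound 1; the only counted step, a 9.9-fold lower number from compound 1 to compound 3 (1.00 log units; beyond the scatter), is the one that leads to it. Compound 4, `O=C(O)CC/C=C\CO[C@H]1C(OCc2ccc(-c3ccccc3CO)cc2)CC[C@@H]1N1CCCCCC1`, carries the change (hydroxymethyl in place of carbamoyl on an aromatic carbon). Among the measured compounds shown here, no measured step covers this swap directly, but compound 2, which also bears the hydroxymethyl group on the same ring, gives 12.6 nM, and compound 3 gives 15.9 nM, two numbers within the scatter of each other. Compound 4 is therefore expected to show no step beyond the scatter, a 1.1-fold lower number from compound 3 to compound 4 (0.06 log units; within the scatter), and its estimate in this assay is 14 nM, within 5 nM to 40 nM.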

Compound 4, dissociation constant: 6.31 nM
Estimate against measurement, compound 4: 2.2-fold (0.35 log units) above, within the range that was stated.
By their numbers in this assay, from the lowest: compounds 4, 2 and 3 (each within the scatter of the next, the first and the last beyond it); then compound 1.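

Hydroxymethyl does better than carbamoyl on this aromatic carbon, with a 2.5-fold lower number from compound 3 to compound 4 (0.40 log units; beyond the scatter), so the position responds to a change that keeps one hydrogen-bond donor and one acceptor. The distance from the carbamoylmethyl compound is far larger, at a 25-fold lower number from compound 1 to compound 4 (1.40 log units; beyond the scatter). The two hydroxymethyl compounds stand within the scatter, at a 2.0-fold lower number from compound 2 to compound 4 (0.30 log units; within the scatter), and that comparison carries a caveat: the fact that one of compounds 2 and 4 is drawn with a defined configuration and the other without, at the place where they differ.

The compounds shown leave open what a defined configuration at that ring carbon contributes. They also leave open how an amine or a carboxylic acid would fare on this aromatic carbon.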